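Para-halogen swap on the phenyl of a tetrabromo series

The compounds below may be only part of what the source reports. "The series", "measured", "known", "first", "only" and "open" are said of these compounds alone.

Measured so far:
compound 1 `OC(CCn1nc2c(Br)c(Br)c(Br)c(Br)c2n1)c1ccc(Br)cc1` — 0%
compound 2 `OC(CCn1nc2c(Br)c(Br)c(Br)c(Br)c2n1)c1ccc(Cl)cc1` — 0%

In a functional assay on CCRF-CEM cells (Homo sapiens) for antiproliferative activity, read by MTT assay, with a stated time of 48 h, tested at 50 uM (on this read-out lower numbers stand for a stronger effect and higher numbers for a weaker effect at the one concentration tested), compound 2 gives 0%, level with compound 1 at the digits shown. Among the measured compounds shown here, the only step measured at this position, no change at the digits printed from compound 1 to compound 2 (within the scatter), is flat. Compound 3 `OC(CCn1nc2c(Br)c(Br)c(Br)c(Br)c2n1)c1ccc(F)cc1` differs from compound 2 by fluoro in place of chloro on an aromatic carbon. That step bears on the same aromatic carbon as the measured one, which moved nothing; a further change of halogen there is therefore expected to leave the read-out unmoved, with no change at the digits printed from compound 2 to compound 3 (within the scatter) as the estimated step. For compound 3 the estimate is 0%, with a range from 0% to 10%.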

Compound 3, a percentage reported as activity, at one concentration (the size of the read-out at that concentration, not a potency): 0%
Compound 3: the middle estimate sits on the measured number at the digits printed, and the stated range covers the measured number.
By their numbers in this assay, from the lowest: compounds 1, 2 and 3 (each within the scatter of the next).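

Reading this assay shows no change at the digits printed from compound 2 to compound 3 (within the scatter) for fluoro in place of chloro and no change at the digits printed from compound 1 to compound 3 (within the scatter) for fluoro in place of bromo on the same aromatic carbon. The flat result at this place, para to a large group, now holds across three halogens and not just one pair. Nothing available here explains why the halogen makes no difference at this place.

Still open, going by these compounds, is whether a group other than a halogen at this place, such as an amine or a carboxylic acid, would move the read-out. The same question stands for a longer chain between the shared core and the phenyl ring.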